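This account rests on a few compounds, and the source may have more. Where it says the series, first, only, none or still open, it means among the compounds named here.

Measured compounds in an ADME assay on L02 cells (Homo sapiens) for antiproliferative activity, read by MTT assay, with a stated time of 48 h; on this read-out lower numbers stand for stronger inhibition and higher numbers for weaker inhibition:
- Compound 1 `CCOc1ccc(-n2nncc2CN2C(=O)C3(C(C#N)=C(N)Oc4c3c3nc5ccccc5nc3c3ccccc43)c3ccccc32)cc1`: compound 1 gives > 50000 nM in this assay, a limit of the assay rather than a number.
- Compound 2 `N#CC1=C(N)Oc2c(c3nc4ccccc4nc3c3ccccc23)C12C(=O)N(Cc1cnnn1-c1ccc(S(N)(=O)=O)cc1)c1ccccc12`: compound 2 gives > 50000 nM in this assay, again a limit.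
- Compound 3 `Cc1cccc(-n2nncc2CN2C(=O)C3(C(C#N)=C(N)Oc4c(N)cc5nc6ccccc6nc5c43)c3ccccc32)c1`: compound 3 gives > 50000 nM in this assay, also a limit.

Compound 3 therefore stands at the limit, alongside the two other values, which are limits as well (the limit of > 50000 nM in this assay, at which 3 of the 3 values shown sit). Among the measured compounds shown here, the only step between measured compounds, a step that the two limits leave unreadable from compound 1 to compound 2, is unreadable in size for the same reason.

Compound 4 `COc1ccc(-n2nncc2CN2C(=O)C3(C(C#N)=C(N)Oc4c(N)cc5nc6ccccc6nc5c43)c3ccccc32)cc1` differs from compound 3 in one place: 4-methoxyphenyl in place of 3-methylphenyl on an aromatic nitrogen. For the measured compounds named here, no measured step bears directly on this change, and the one step available gives no readable size. The shared outcome of compound 1, compound 2 and compound 3 the limit of > 50000 nM in this assay, at which 3 of the 3 values shown sit, gives no ground to expect compound 4 to move beyond the scatter, so the step that the limit leaves unreadable from compound 3 to compound 4 is expected to be none beyond the scatter.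

Compound 4 is thus estimated at 60000 nM in this assay, with a range from 20000 nM to 200000 nM, most likely reported as a limit.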

Compound 4, half-maximal inhibitory concentration: > 50000 nM
Compound 4: a limit, no number; the forecaster's own chance of this, stated with the estimate: 85%; the middle value does not contradict the limit.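

In this assay, among the compounds shown here, compound 4 gives > 50000 nM, a limit and not a number, so no step from compound 3 to compound 4 can be read. The compounds shown leave open how far each lies beyond the limit and which change, if any, would give a measurable value.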